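The source may hold more compounds than are shown below. What is called first, only, known or untested is meant among the compounds shown, and "the series" means these compounds.

Measured so far in an ADME assay on Vero cells (Chlorocebus sabaeus) for cytotoxicity, read by WST assay, tested at 50 ug/mL; a higher number here means a weaker effect of the compound at the concentration tested, a lower number a stronger effect:

Compound 1 `Cc1ccc(/C=C/C(=O)O/C(=N/C2CCCCC2)NC2CCCCC2)cc1` gives 79.3%.
Compound 2 `O=C(/C=C/c1ccccc1)O/C(=N/C1CCCCC1)NC1CCCCC1` gives 83.9%.
Compound 3 `COC(=O)[C@@H]1COC(/C=C/c2ccc(C)cc2)=N1` gives 85.1%.

Compounds 1 and 2 share one core and differ in a single place: hydrogen in place of methyl on an aromatic carbon. The resulting step is a number 4.6 percentage points higher from compound 1 to compound 2 (within the scatter), so within this pair the change leaves the read-out essentially where it was. Compound 3 sits on a second core; the difference between the two cores is not broken down here. All three numbers lie within the scatter of one another, so no order among compounds 1, 2 and 3 is claimed.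

Compound 4 `COC(=O)[C@@H]1COC(/C=C/c2ccccc2)=N1` has not been measured. It is obtained from compound 3 by hydrogen in place of methyl on an aromatic carbon, and the place of this change reads word for word as in the pair of compounds 1 and 2, so it is the same change carried onto the second core. For the measured compounds named here, the one observed instance of it, a number 4.6 percentage points higher from compound 1 to compound 2 (within the scatter), is within the scatter.

Going by the values given here, on that basis the step from compound 3 to compound 4 is expected to be a number 1.9 percentage points higher from compound 3 to compound 4 (within the scatter), resting on the single earlier instance a number 4.6 percentage points higher from compound 1 to compound 2 (within the scatter) and on the value of compound 3, 85.1%. Compound 4 is accordingly estimated at 87% in this assay, with the expected range running from 75% to 97%. The estimate rests on one prior pair only, and that pair stands on a different core, so the range is kept wide.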

Compound 4, a percentage reported as activity, at one concentration (the size of the read-out at that concentration, not a potency): 68.6%
The estimate for compound 4 lay 18.4 percentage points above the measured number; the measured number lies below the stated range.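

In this assay, hydrogen in place of methyl on an aromatic carbon gives a number 16.5 percentage points lower from compound 3 to compound 4 (beyond the scatter), so on the core of compound 3 this change shifts the read-out towards a stronger effect at the concentration tested. The same change therefore does not carry over with one size from the core of compound 1 to the core of compound 3, and the two steps differ: the same change on two cores in this assay, a number 4.6 percentage points higher (within the scatter) from compound 1 to compound 2 and a number 16.5 percentage points lower (beyond the scatter) from compound 3 to compound 4, 21.1 percentage points apart, beyond the scatter of two such steps This shows that, in this series, a step read on one core is a poor guide to the step on the other, but it does not show which feature of the two cores accounts for the difference, and with a single pair on each core it gives no general rule for any further core.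

The compounds shown leave open whether the dependence on the core holds for other groups at the same place on the aromatic ring, such as chlorine or methoxy. They also leave open how the step would read on the core of compound 3 with a carboxylic acid or an amide in place of the methyl ester.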